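Moving a Hydroxyl Across the Phenyl Ring

A few compounds are considered here, and "the series" means these few. Any claim that something is new, unique, unknown or untested is made for them only; others in the source may bear on it.

Of the compounds shown here, three share one core and have been tested in an assay on isolated protein for inhibition of DNA topoisomerase 1 (Homo sapiens), with a stated time of 30 min, tested at 100 uM; a lower number here means a weaker effect, a higher number a stronger effect of the compound at the concentration tested. Compound 1 `Oc1ccc(-c2cc(-c3cccs3)cc(-c3ccc(O)cc3)n2)cc1` gives 86.3%, compound 2 `Oc1ccc(-c2cc(-c3ccccn3)cc(-c3ccc(O)cc3)n2)cc1` gives 1.4%, and compound 3 `Oc1ccc(-c2cc(-c3cccnc3)cc(-c3ccccc3O)n2)cc1` gives 1.5%. Compound 3 thus stands second highest of the three, within the scatter of compound 2 and well below compound 1. For the measured compounds named here, the only step between two compounds that differ in one place, a number 84.9 percentage points lower from compound 1 to compound 2 (beyond the scatter), concerns a different position from the one considered here.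

Compound 4 `Oc1ccc(-c2cc(-c3cccnc3)cc(-c3ccc(O)cc3)n2)cc1` differs from compound 3 by 4-hydroxyphenyl in place of 2-hydroxyphenyl on an aromatic carbon. Going by the values given here, no measured step bears directly on this change, so the expectation rests on the neighbours: compound 2, which also carries two 4-hydroxyphenyl groups and a pyridyl group, gives 1.4%, and compound 3 gives 1.5%. Compound 4 is therefore expected to stay near those low numbers, with the step of a number 3.5 percentage points higher from compound 3 to compound 4 (within the scatter) estimated as within the scatter. The estimate for compound 4 in this assay is 5%, ranging from 0% to 25%.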

Compound 4, a percentage reported as inhibition, at one concentration (the size of the read-out at that concentration, not a potency): 8.7%
Beside the measured number, compound 4's estimate is 3.7 percentage points below it, and the stated range covers the measured number.
By their numbers in this assay, from the lowest: compounds 2, 3 and 4 (each within the scatter of the next); then compound 1.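

In this assay, exchanging 2-hydroxyphenyl for 4-hydroxyphenyl at this place next to the ring nitrogen gives a number 7.2 percentage points higher from compound 3 to compound 4 (within the scatter), so the two groups are not told apart while pyridin-3-yl is present. The other two new steps separate the change of ring from the change of nitrogen place: exchanging pyridin-2-yl for pyridin-3-yl gives a number 7.3 percentage points higher from compound 2 to compound 4 (within the scatter), whereas exchanging thiophen-2-yl for pyridin-3-yl gives a number 77.6 percentage points lower from compound 1 to compound 4 (beyond the scatter). No measurement at hand explains either the large step or the small ones.

The compounds shown leave open whether 2-hydroxyphenyl would also match 4-hydroxyphenyl with thiophen-2-yl on the core, where the read-out is not near the floor. They also leave open what a methoxy group, an amine or a carboxylic acid would do in place of the hydroxyl.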